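Swapping Benzyl for 4-Iodophenyl on the Amine Nitrogen

The source may report more compounds than this note shows. Statements on the series, on what has been measured and on what is new or still open speak of the compounds shown alone.

Compound 1 `O=C1C=C(NCc2ccccc2)C(=O)c2c1nc1n2[C@H]2OC[C@@H](O)[C@H]2OC1` is the starting point. In a functional assay on HeLa cells (Homo sapiens) for inhibition, read by sulforhodamine B assay (on this read-out lower numbers stand for stronger inhibition and higher numbers for weaker inhibition), compound 1 gives > 8000 nM, which is a limit of the assay rather than a number. Two anilines share its core. Compound 2 `Cc1ccc(NC2=CC(=O)c3c(nc4n3[C@H]3OC[C@@H](O)[C@H]3OC4)C2=O)cc1` gives 6590 nM in this assay, and compound 3 `O=C1C(Nc2ccc(C(F)(F)F)cc2)=CC(=O)c2c1nc1n2[C@H]2OC[C@@H](O)[C@H]2OC1` gives 8920 nM. Among the compounds with values here, the one measured step between them, a 1.4-fold higher number from compound 2 to compound 3 (0.13 log units; within the scatter), changes little, and both anilines sit near the limit of the limit of > 8000 nM in this assay, at which 1 of the 3 values shown sits.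

Compound 4 `O=C1C=C(Nc2ccc(I)cc2)C(=O)c2c1nc1n2[C@H]2OC[C@@H](O)[C@H]2OC1` carries the change (4-iodophenyl in place of benzyl on an amine nitrogen); cut one bond further out, benzylamino becomes (4-iodophenyl)amino. Within the data shown here, no measured step covers this particular change, so the expectation rests only on where the anilines compound 2 and compound 3 stand, both weak inhibitors. The expected step is therefore an at least 1.0-fold lower number from compound 1 to compound 4 (0.02 log units; that floor lies within the scatter), meaning nothing beyond the scatter of repeated measurements. For compound 4 the estimated value is 7500 nM, with a range from 3000 nM to 20000 nM, and a real chance that only a limit is reported.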

Compound 4, half-maximal inhibitory concentration: 4070 nM
Compound 4: the middle estimate sits 1.8-fold (0.27 log units) above what was measured; the range from low to high includes it.
By their numbers in this assay, from the lowest: compounds 4, 2 and 3 (each within the scatter of the next, the first and the last beyond it).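

Within the data shown here, putting 4-iodophenyl in place of benzyl on this amine nitrogen gives the first step that links the benzylamino compound to an aniline, an at least 1.9-fold lower number from compound 1 to compound 4 (0.29 log units; that floor lies within the scatter), and so replaces a limit with a measured number. The step can be stated only as a floor because compound 1 stands at a limit of the assay: the limit of > 8000 nM in this assay, at which 1 of the 4 values shown sits. A real gain from this change is therefore possible but not shown, and compound 4 remains within the scatter of compound 2, so the anilines shown stay weak inhibitors.

On these data alone, the true size of the step remains open, as does whether a carboxylic acid or an amine in place of the iodine would change the number. A longer chain on this nitrogen, such as 2-phenylethyl, is equally untested among the compounds shown.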